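The source may report more compounds than this note shows. Statements on the series, on what has been measured and on what is new or still open speak of the compounds shown alone.

Compound 3 `COc1cccc(CNCCCNc2ccnc3cc(Oc4ccc(F)cc4)ccc23)c1O` sits level with its two neighbours in a physicochemical assay for acid dissociation: compound 3 gives 9.28, compound 1 `COc1ccccc1Oc1ccc2c(NCCCNCc3ccco3)ccnc2c1` gives 9.28, and compound 2 `COc1cccc(CNCCCNc2ccnc3cc(Oc4cccc(N(C)C)c4)ccc23)c1O` gives 9.28. Going by the values given here, the one step recorded between them, no change at the digits printed from compound 2 to compound 3 (within the scatter), lies within the scatter. Compound 4 `COc1ccccc1Oc1ccc2c(NCCCNCc3cccc(OC)c3O)ccnc2c1` differs from compound 3 by 2-methoxyphenyl in place of 4-fluorophenyl on an oxygen on an aromatic ring, the same kind of exchange on the aryl ether oxygen that the step from compound 2 to compound 3 already covers, while the amine chain that carries the measured proton is untouched. Compound 4 is therefore expected to show no step beyond the scatter, no change at the digits printed from compound 3 to compound 4 (within the scatter), in this assay. Compound 4 is estimated at 9.28, between 9 and 9.55.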

Compound 4, acid dissociation constant: 9.28
Compound 4: middle estimate and measured number agree at the digits printed; measured number inside the range.
By their numbers in this assay, from the lowest: compounds 1, 2, 3 and 4 (each within the scatter of the next).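

In this assay, 2-methoxyphenyl on an oxygen on an aromatic ring gives no change at the digits printed from compound 3 to compound 4 (within the scatter) and no change at the digits printed from compound 2 to compound 4 (within the scatter), so 4-fluorophenyl, 3-(dimethylamino)phenyl and 2-methoxyphenyl now read alike at this place. The first step at the other place shown, 2-hydroxy-3-methoxyphenyl in place of furan-2-yl on a saturated chain carbon bound to an amine nitrogen, gives no change at the digits printed from compound 1 to compound 4 (within the scatter) as well. No evidence at hand accounts for these matching readings. From the compounds shown here alone, whether a carboxylic acid on that oxygen-bearing ring, or a longer chain carrying the amine nitrogens, would shift the reading stays open.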